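This account rests on a few compounds, and the source may have more. Where it says the series, first, only, none or still open, it means among the compounds named here.

Measured in an ADME assay on HepG2 cells (Homo sapiens) for cytotoxicity, with a stated time of 72 h; on this read-out higher numbers stand for an effect only at larger amounts of compound and lower numbers for an effect already at smaller amounts:
- Compound 1 `CC(=O)c1ccc(NC(=O)Nc2cc(C)nc3ccccc23)cc1`: 19000 nM
- Compound 2 `Cc1cc(NC(=O)Nc2ccc(N(C)C)cc2)c2ccccc2n1`: > 25000 nM (a limit, not a number)
- Compound 3 `COC(=O)c1ccc(NC(=O)Nc2cc(C)nc3ccccc23)cc1`: 20000 nM

Compound 3 gives 20000 nM and compound 1 gives 19000 nM, so the two values lie within the scatter of each other. Within the data shown here, these are the only two actual numbers so far.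

The next change leads to compound 4 `Cc1cc(NC(=O)Nc2ccc(OC(F)(F)F)cc2)c2ccccc2n1`, with trifluoromethoxy in place of methoxycarbonyl on an aromatic carbon, para to a large group: trifluoromethoxy in place of methoxycarbonyl on an aromatic carbon.

Among the measured compounds shown here, three measured steps bear on this. Two exchange the group on that aromatic carbon: an at least 1.3-fold higher number from compound 1 to compound 2 (0.11 log units; that floor lies within the scatter) and an at least 1.2-fold lower number from compound 2 to compound 3 (0.09 log units; that floor lies within the scatter). The third alters only the carbonyl substituent: a 1.1-fold higher number from compound 1 to compound 3 (0.02 log units; within the scatter). None of them goes beyond the scatter, although trifluoromethoxy itself has not been tested in this series. No step beyond the scatter is therefore expected in this assay, though a lower number remains possible.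

The expected change is a 1.3-fold lower number from compound 3 to compound 4 (0.12 log units; within the scatter). The estimate for compound 4 is 15000 nM, with an expected range from 6000 nM to 25000 nM.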

Compound 4, half-maximal effective concentration: 15000 nM
Compound 4: the middle estimate sits on the measured number at the digits printed, and the stated range covers the measured number.
By their numbers in this assay, from the lowest: compounds 4, 1 and 3 (each within the scatter of the next). At a limit, above all of these: compound 2.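

In this assay, trifluoromethoxy on this aromatic carbon, para to a large group, extends the exchange to a group carrying fluorine and no carbonyl, and the steps against both carbonyl groups are small: a 1.3-fold lower number from compound 3 to compound 4 (0.12 log units; within the scatter) and a 1.3-fold lower number from compound 1 to compound 4 (0.10 log units; within the scatter). With compound 4, three actual numbers now sit within the scatter of one another, so no exchange at this position has yet produced a step beyond the scatter. The comparison with dimethylamino gives only a floor, an at least 1.6-fold lower number from compound 2 to compound 4 (0.22 log units; that floor lies within the scatter), and not a measured difference: the limit of > 25000 nM in this assay, at which 1 of the 4 values shown sits.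

Going by these compounds, whether a carboxylic acid, a primary amine or a longer chain on this aromatic carbon would produce a step beyond the scatter remains open. Also open, on these data alone, is whether changes elsewhere on the shared core would move the number more than exchanges at this position do.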